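This account rests on a few compounds, and the source may have more. Where it says the series, first, only, none or still open, it means among the compounds named here.

Compound 1 `O=C(NNc1ccccc1Cl)C12C3C=CC4C3C3C(C=CC31)C42` is tested in an assay on HEK293 cells for antagonist activity at P2X purinoceptor 7 (Homo sapiens), read by fluorescence, with a stated time of 2 h (a lower number here means a stronger inhibitor, a higher number a weaker inhibitor), where compound 1 gives 96000 nM. For the measured compounds named here, its only companion is compound 2 `O=C(NNc1ccccc1C(F)(F)F)C12C3C=CC4C3C3C(C=CC31)C42`, which in this assay gives 132000 nM; the step of a 1.4-fold higher number from compound 1 to compound 2 (0.14 log units; within the scatter) leaves the two within the scatter of one another. Compound 3 `O=C(NNc1ccc(C(F)(F)F)cc1Cl)C12C3C=CC4C3C3C(C=CC31)C42` differs from compound 1 by trifluoromethyl in place of hydrogen on an aromatic carbon. Going by the values given here, no measured step bears directly on this change; the single step seen, exchanging chloro for trifluoromethyl at the same carbon, stayed within the scatter. For compound 3 no step beyond the scatter is expected, a 1.1-fold lower number from compound 1 to compound 3 (0.03 log units; within the scatter), and the estimate is 90000 nM with a range from 30000 nM to 300000 nM.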

Compound 3, half-maximal inhibitory concentration: 1560000 nM
For compound 3 the middle estimate is 17-fold (1.24 log units) below the measured one; measured number above the stated range.
By their numbers in this assay, from the lowest: compounds 1 and 2 (each within the scatter of the next); then compound 3.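

In this assay, trifluoromethyl on this aromatic carbon, meta to a chloro group and para to a large group, gives a 16-fold higher number from compound 1 to compound 3 (1.21 log units; beyond the scatter). The earlier pair showed only an exchange of chloro for trifluoromethyl on another carbon, within the scatter, whereas this added group leaves compound 3 a clearly weaker inhibitor. No measurement at hand bears on why the number rises. Going by these compounds, whether this rise belongs to the position or to trifluoromethyl itself stays open. A fluoro, methyl or amine group on the same carbon could separate the two.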